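Cytotoxicity of a quinazoline amide pair in fibroblast cells

This account rests on a few compounds, and the source may have more. Where it says the series, first, only, none or still open, it means among the compounds named here.

Measured compounds:
Compound 1 `Nc1nc(-c2ccc(Cl)cc2)nn1-c1ncnc2cc(Cl)ccc12`: > 47000 nM
Compound 2 `COc1cc2ncnc(-n3nc(-c4ccc(Cl)cc4)cc3N)c2cc1OC`: "not determined" (no result reported)
Compound 3 `COc1cc2ncnc(-n3nc(-c4ccccn4)nc3N)c2cc1OCCCNC(=O)CN1C[C@@H](C)O[C@@H](C)C1`: > 25000 nM

In an ADME assay on BJ cells (Homo sapiens) for cytotoxicity, with a stated time of 72 h (on this read-out lower numbers stand for an effect already at smaller amounts and higher numbers for an effect only at larger amounts of compound), compound 1 gives > 47000 nM, which is a limit of the assay rather than a number. Compound 2 gives "not determined" (no result reported) in this assay. Compound 3 gives > 25000 nM in this assay, again a limit and not a number. Compound 3 therefore stands only at a limit, and nothing finer can be said of its position among the three: the other two entries are another limit of > 47000 nM in this assay, at which 1 of the 3 values shown sits, and an entry without a number.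

Compound 4 `COc1cc2ncnc(-n3nc(-c4ccccn4)nc3N)c2cc1OCCCNC(=O)C(F)(F)F` differs from compound 3 in one place: trifluoromethyl in place of (2,6-dimethylmorpholin-4-yl)methyl on a carbonyl carbon. No step between measured compounds is shown that would tell how such a change acts in this assay. Since compound 3 sits at a limit (the limit of > 25000 nM in this assay, at which 1 of the 3 values shown sits), the step from compound 3 to compound 4 is expected to show no change beyond the scatter, with a step that the limit leaves unreadable from compound 3 to compound 4. Compound 4 is thus estimated at 30000 nM, within 10000 nM to 60000 nM, and most likely the assay will again report only a limit.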

Compound 4, half-maximal effective concentration: > 7000 nM
Compound 4: no number, only a limit (the forecaster's own chance of this, stated with the estimate: 70%); the middle value is on the limit's open side.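

In this assay, among the compounds shown here, compound 3 and compound 4 both stand only at limits, not numbers, so no step between them can be read. The compounds shown leave open whether trifluoromethyl in place of (2,6-dimethylmorpholin-4-yl)methyl on a carbonyl carbon changes the cytotoxicity read-out at all.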